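A Thiophenyl Group Replaces Fluorophenyl on the Shared Core

The source may hold more compounds than are shown below. What is called first, only, known or untested is meant among the compounds shown, and "the series" means these compounds.

Compound 1 `Cc1ccc(-c2nc(CNc3ccc(C(=O)NO)cc3)n(-c3ccccc3)n2)cc1` gives 62.2%
Compound 2 `CC(C)c1ccc(-n2nc(-c3ccccc3)nc2CNc2ccc(C(=O)NO)cc2)cc1` gives 52.6%
Compound 3 `O=C(NO)c1ccc(NCc2nc(-c3ccc(F)cc3)nn2-c2ccccc2)cc1` gives 70.9%

These three compounds were measured in an assay on Sf9 cells for inhibition of protein deacetylase HDAC6 (Homo sapiens), read by fluorescence, with a stated time of 40 min, tested at 100 nM; on this read-out higher numbers stand for more inhibition at the one concentration tested (going by the name of the read-out) and lower numbers for less inhibition. Compound 3 has the largest of the three numbers, but its gap to compound 1 is within the scatter, so the two cannot be told apart; only compound 2 lies beyond the scatter below it. Among the measured compounds shown here, the single step between compounds differing in one place, a number 8.7 percentage points higher from compound 1 to compound 3 (within the scatter), exchanges one small group for another on the same aromatic ring and is within the scatter.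

Compound 4 `O=C(NO)c1ccc(NCc2nc(-c3ccsc3)nn2-c2ccccc2)cc1` has not yet been measured in this assay. It differs from compound 3 as follows: thiophen-3-yl in place of 4-fluorophenyl on an aromatic carbon. For the measured compounds named here, no measured step exchanges this ring for a different one, so the data give no direct guide to the size of the change. Going by the values given here, the one step that touches this part of the molecule was within the scatter. A step within the scatter is therefore expected for a number 7.9 percentage points lower from compound 3 to compound 4 (within the scatter), with a wide range to allow for the unknown. Compound 4 is expected to give about 63%, between 42% and 80%.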

Compound 4, a percentage reported as inhibition, at one concentration (the size of the read-out at that concentration, not a potency): 53.4%
Compound 4: the middle estimate sits 9.6 percentage points above what was measured; low and high end bracket the measured number.
By their numbers in this assay, from the lowest: compounds 2, 4, 1 and 3 (each within the scatter of the next, the first and the last beyond it).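

The earlier compounds shown here only exchanged a small group on a phenyl ring that stayed in place, whereas here the whole ring changes, from a six-membered ring of carbon only to a five-membered ring holding sulfur, and in this assay this gives a number 17.5 percentage points lower from compound 3 to compound 4 (beyond the scatter). This shows that the read-out can respond to the ring at this position on the shared core, but the same thiophen-3-yl group set against 4-methylphenyl gives a number 8.8 percentage points lower from compound 1 to compound 4 (within the scatter), so the thiophene ring lowers the number clearly only when compound 3 is the reference, and there is no general loss on leaving a phenyl ring. The data offer no measurement that explains the difference seen with either partner.

The compounds shown leave open how other rings at this position would read, such as a pyridine ring or a non-aromatic cyclohexyl group, and whether a second thiophene attachment, reached through the thiophen-2-yl group, would read like thiophen-3-yl. With a single tested concentration, they also leave open how far these percentages reflect differences in potency.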